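A few compounds are considered here, and "the series" means these few. Any claim that something is new, unique, unknown or untested is made for them only; others in the source may bear on it.

Compound 3 `COc1nc(-c2ccc(F)cc2)ccc1[C@@H](c1ccccc1)[C@@](O)(CCN(C)C)c1cccc2ccccc12` gives in a toxicity assay on Vero cells (Chlorocebus sabaeus) for cytotoxicity (on this read-out lower numbers stand for higher toxicity in this test and higher numbers for lower toxicity in this test), only a limit, > 50 ug/mL. Compound 1 `COc1nc(-c2ccccc2F)ccc1[C@@H](c1ccccc1)[C@@](O)(CCN(C)C)c1cccc2ccccc12` also gives only a limit in this assay, > 50 ug/mL. Compound 2 `COc1nc(-c2ccncc2)ccc1[C@@H](c1ccccc1)[C@@](O)(CCN(C)C)c1cccc2ccccc12` likewise stops at a limit in this assay, > 50 ug/mL. All three sit at the limit of > 50 ug/mL in this assay, at which 3 of the 3 values shown sit. The steps a step that the two limits leave unreadable from compound 1 to compound 2, a step that the two limits leave unreadable from compound 1 to compound 3 and a step that the two limits leave unreadable from compound 2 to compound 3 therefore cannot be sized. Compound 4 `COc1nc(-c2ccc(C#N)cc2)ccc1[C@@H](c1ccccc1)[C@@](O)(CCN(C)C)c1cccc2ccccc12` differs from compound 3 by cyano in place of fluoro on an aromatic carbon. Within the data shown here, none of the measured steps touches this change, and the three compounds closest to it all stop at the limit of this assay. The expected step that the limit leaves unreadable from compound 3 to compound 4 in this assay is therefore none beyond the scatter. Compound 4 is expected to give about 60 ug/mL, within 30 ug/mL to 150 ug/mL, most likely again reported as a limit.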

Compound 4, half-maximal cytotoxic concentration: > 50 ug/mL
Compound 4: only a limit was reported (the forecaster's own chance of this, stated with the estimate: 80%); the middle value is on the limit's open side.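

Compound 4, like compound 1, compound 2 and compound 3, stops at a limit in this assay, so no step between them can be read: the limit of > 50 ug/mL in this assay, at which 4 of the 4 values shown sit.

On these data alone, how far each compound's true value lies past that limit stays open, as does whether these groups differ at all in this read-out.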